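Working notes: side-chain changes on a shared core, compounds 1 to 4

A few compounds are considered here, and "the series" means these few. Any claim that something is new, unique, unknown or untested is made for them only; others in the source may bear on it.

Measured in an in vitro functional assay on HEK293S cells for agonist activity at Glucose-dependent insulinotropic receptor (Homo sapiens), read by HTRF and cAMP accumulation, with a stated time of 45 min; on this read-out higher numbers stand for an effect only at larger amounts of compound and lower numbers for an effect already at smaller amounts:
- compound 1 `C[C@@H]1CN(c2ncc(OCc3ccc(S(C)(=O)=O)cc3)cn2)CCN1C(=O)OC(C)(C)C`: 54 nM
- compound 2 `CC(C)(C)OC(=O)N1C[C@@H]2C[C@H]1CN2c1ncc(OCc2ccc(S(C)(=O)=O)cc2)cn1`: 2220 nM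
- compound 3 `C[C@@H]1CN(C(=O)OC(C)(C)C)CCN1c1ncc(OCC2CCN(S(C)(=O)=O)CC2)cn1`: 29 nM

Compound 3 gives the lowest number of the three. Its nearest neighbour is compound 1, whose value lies within the scatter of that of compound 3, so no order between these two can be read. Compound 2 stands far apart from compound 3, beyond the scatter, and is the weakest of the three.

Compound 4 `Cc1cnccc1COc1cnc(N2CCN(C(=O)OC(C)(C)C)C[C@H]2C)nc1` has not been measured. It differs from compound 3 in one place: 3-methylpyridin-4-yl in place of 1-(methylsulfonyl)piperidin-4-yl on a saturated chain carbon bound to an oxygen on an aromatic ring. Going by the values given here, no measured pair shows this change, so the expectation rests on compounds 1 and 3 only, which show that a ring without a second substituent on the ether-linked group has not yet been tested. A step in the direction of larger amounts of compound is expected, of modest size, a 3.8-fold higher number from compound 3 to compound 4 (0.58 log units; beyond the scatter), beyond the scatter but not large. The expected value for compound 4 in this assay is 110 nM, with a range from 30 nM to 450 nM.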

Compound 4, half-maximal effective concentration: 184 nM
Compound 4: the middle estimate sits 1.7-fold (0.22 log units) below what was measured; measured number inside the range.
By their numbers in this assay, from the lowest: compounds 3 and 1 (each within the scatter of the next); then compound 4; then compound 2.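

In this assay, 3-methylpyridin-4-yl in place of 1-(methylsulfonyl)piperidin-4-yl on a saturated chain carbon bound to an oxygen on an aromatic ring gives a 6.3-fold higher number from compound 3 to compound 4 (0.80 log units; beyond the scatter), a modest step beyond the scatter. This is the only single-place change shown at this position, and it indicates that a six-membered aromatic ring with one hetero atom and no sulfonyl group is tolerated here, with agonist activity kept at a moderate cost. Nothing measured on these compounds accounts for the size of the step.

On these data alone, the step changes the ring and removes the methylsulfonyl group together, so the share of each stays open. A plain pyridin-4-yl, without the methyl group, and a piperidin-4-yl carrying an acetyl group in place of methylsulfonyl would each separate one part of this change.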